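From Phenylethenylcarbonyl to Fluorophenylsulfonyl on a Ring Nitrogen

The compounds below may be only part of what the source reports. "The series", "measured", "known", "first", "only" and "open" are said of these compounds alone.

Compound 1 `CCN(CC)c1ccc2cc(C(=O)c3ccc(N4CCN(C(=O)CN5CCN(C(=O)/C=C/c6ccccc6)CC5)CC4)cc3)oc2c1` is the starting point. Going by the values given here, in a functional assay on HeLa cells (Homo sapiens) for cytotoxicity, read by MTT assay, with a stated time of 48 h (a lower number here means a stronger inhibitor, a higher number a weaker inhibitor), compound 1 gives 5260 nM, the lowest of the two numbers known here. Its nearest neighbour is compound 3 `CCN(CC)c1ccc2cc(C(=O)c3ccc(N4CCN(C(=O)CN5CCN(S(=O)(=O)c6ccc(C#N)cc6)CC5)CC4)cc3)oc2c1`, which gives 8470 nM; the step of a 1.6-fold higher number from compound 1 to compound 3 (0.21 log units; within the scatter). Compound 2 `CCN(CC)c1ccc2cc(C(=O)c3ccc(N4CCN(C(=O)CN5CCN(S(=O)(=O)c6ccc(C(F)(F)F)cc6)CC5)CC4)cc3)oc2c1` is known only as a limit of the assay, > 40000 nM, which is the limit of > 40000 nM in this assay, at which 1 of the 3 values shown sits. The step of an at least 4.7-fold lower number from compound 2 to compound 3 (0.67 log units; beyond the scatter) shows that the group on the aromatic ring of the sulfonyl part can move the number far. Compound 4 `CCN(CC)c1ccc2cc(C(=O)c3ccc(N4CCN(C(=O)CN5CCN(S(=O)(=O)c6ccc(F)cc6)CC5)CC4)cc3)oc2c1` differs from compound 1 by (4-fluorophenyl)sulfonyl in place of (2-phenylethenyl)carbonyl on an amine nitrogen in a ring. This resembles the change behind a 1.6-fold higher number from compound 1 to compound 3 (0.21 log units; within the scatter), with fluorine in place of cyano, so a modestly higher number is expected, with the possibility of a larger loss. Compound 4 is therefore estimated to give 12000 nM, within 5000 nM to 40000 nM, an expected step of a 2.3-fold higher number from compound 1 to compound 4 (0.36 log units; beyond the scatter).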

Compound 4, half-maximal inhibitory concentration: 16700 nM
Beside the measured number, compound 4's estimate is 1.4-fold (0.14 log units) below it; the range from low to high includes it.
By their numbers in this assay, from the lowest: compounds 1, 3 and 4 (each within the scatter of the next, the first and the last beyond it). At a limit, above all of these: compound 2.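

With (4-fluorophenyl)sulfonyl on the ring nitrogen, the change from the (2-phenylethenyl)carbonyl group now gives a step beyond the scatter, a 3.2-fold higher number from compound 1 to compound 4 (0.50 log units; beyond the scatter), which the cyano-bearing sulfonyl did not. Fluoro in place of cyano on the aromatic carbon remains within the scatter, a 2.0-fold higher number from compound 3 to compound 4 (0.29 log units; within the scatter), so these two groups are not separated. Fluoro in place of trifluoromethyl gives an at least 2.3-fold lower number from compound 2 to compound 4 (0.37 log units; beyond the scatter), and this step is open-ended, as compound 2 stands at a limit: the limit of > 40000 nM in this assay, at which 1 of the 4 values shown sits.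

The compounds shown leave open how an amine or a carboxylic acid on that aromatic carbon would read. They also leave open whether a longer chain on the ring nitrogen would keep the number near that of compound 1.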